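Benzyl for tert-butyl ester: expected shift in adenosine binding

The source may hold more compounds than are shown below. What is called first, only, known or untested is meant among the compounds shown, and "the series" means these compounds.

Measured compounds:
Compound 1, `CC1=C(C(=O)OC(C)(C)C)C(c2ccsc2)NC(=O)N1`: 15%
Compound 2, `CC1=C(C(=O)OCc2ccccc2)C(c2ccsc2)NC(=O)N1`: 57%
Compound 3, `CC1=C(C(=O)OC(C)(C)C)C(c2ccoc2)NC(=S)N1`: 18%

In an assay on membranes from CHO cells for displacement of a labelled ligand from adenosine receptor A1 (Homo sapiens), read by scintillation counting, with a stated time of 60 min, tested at 1 uM (a lower number here means less inhibition, a higher number more inhibition at the concentration tested (going by the name of the read-out)), compound 1 gives 15% and compound 2 gives 57%. Within the data shown here, the two differ by benzyl in place of tert-butyl on an oxygen next to a carbonyl group, and the step of a number 42 percentage points higher from compound 1 to compound 2 (beyond the scatter) is the only measured step with this change. Compound 3, in this assay, gives 18%, a number close to that of compound 1 and well apart from that of compound 2. The difference between the core of compound 3 and the core of compound 1 is not broken down here.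

Compound 4, `CC1=C(C(=O)OCc2ccccc2)C(c2ccoc2)NC(=S)N1`, has not yet been measured in this assay. It differs from compound 3 by benzyl in place of tert-butyl on an oxygen next to a carbonyl group, the same change that separates compound 1 from compound 2, at the same place. Because the step of a number 42 percentage points higher from compound 1 to compound 2 (beyond the scatter) was large, and because compound 3 starts from 18%, near the starting point of compound 1, a step of similar direction and size is expected from compound 3 to compound 4, namely a number 37 percentage points higher from compound 3 to compound 4 (beyond the scatter). This expectation rests on a single measured pair, so the range is wide. Compound 4 is estimated to give 55% in this assay, expected to lie between 30% and 75%.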

Compound 4, a percentage reported as inhibition, at one concentration (the size of the read-out at that concentration, not a potency): 25%
Compound 4: the middle estimate sits 30 percentage points above what was measured; measured number outside the range, below it.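

In this assay, putting benzyl in place of tert-butyl on an oxygen next to a carbonyl group gives a number 7 percentage points higher from compound 3 to compound 4 (within the scatter), so the large rise seen on the core of compound 1 does not reappear on the core of compound 3. Set side by side, the two results show that the size of this step in the series depends on the core that carries it, and that the step measured on one core could not be transferred to the other: the same change on two cores in this assay, a number 42 percentage points higher (beyond the scatter) from compound 1 to compound 2 and a number 7 percentage points higher (within the scatter) from compound 3 to compound 4, 35 percentage points apart, beyond the scatter of two such steps What this does not show is which feature of the core matters, as the core of compound 1 and the core of compound 3 are not separated into single changes here, and two pairs give no general rule for how the change behaves on any further core.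

The compounds shown leave open how each difference between these two cores, taken alone, affects the benzyl step. They also leave open how the read-out would respond to other groups at this place, such as a longer chain like n-hexyl, or to an amide or a carboxylic acid in place of the ester.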